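The source may hold more compounds than are shown below. What is called first, only, known or untested is meant among the compounds shown, and "the series" means these compounds.

In a functional assay on A549 cells (Homo sapiens) for cytotoxicity (a higher number here means that more compound is needed for the effect, a lower number that less compound is needed), compound 1 `COC1=C(C)C(=O)/C(=C(O)/C=C/c2ccc(OC)cc2)C(=O)C1(C)C` gives 3 ug/mL and compound 2 `COC1=C(C)C(=O)/C(=C(O)/C=C/c2ccc(F)cc2)C(=O)C1(C)C` gives 3.3 ug/mL. For the measured compounds named here, compound 2 therefore stands level with compound 1, the only other measured compound, and the two cannot be told apart. Compound 3 `COC1=C(C)C(=O)/C(=C(O)/C=C/c2ccco2)C(=O)C1(C)C` keeps the shared core and differs from compound 2 at one place: furan-2-yl in place of 4-fluorophenyl on a double-bonded chain carbon bound to a double-bonded chain carbon. In words, this is furan-2-yl in place of 4-fluorophenyl on a double-bonded chain carbon bound to a double-bonded chain carbon. Going by the values given here, one measured step bears on this change: a 1.1-fold higher number from compound 1 to compound 2 (0.04 log units; within the scatter), with fluoro in place of methoxy on an aromatic carbon. That step exchanges a substituent on the aromatic ring, whereas compound 3 exchanges the whole aromatic group, so it is indirect evidence. Among the compounds with values here, no measured compound carries a five-membered aromatic ring. With only a 1.1-fold higher number from compound 1 to compound 2 (0.04 log units; within the scatter) to go on, no step beyond the scatter is expected in this assay, although the range stays wide. The expected step is a 1.1-fold higher number from compound 2 to compound 3 (0.03 log units; within the scatter). For compound 3 the estimated value is 3.5 ug/mL, with an expected range from 1.5 ug/mL to 8 ug/mL.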

Compound 3, concentration for half-maximal effect: 10 ug/mL
Estimate against measurement, compound 3: 2.9-fold (0.46 log units) below, outside the stated range (above it).
By their numbers in this assay, from the lowest: compounds 1 and 2 (each within the scatter of the next); then compound 3.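

In this assay, the place on a double-bonded chain carbon bound to a double-bonded chain carbon now shows a response to the aromatic group itself: furan-2-yl in place of 4-fluorophenyl gives a 3.0-fold higher number from compound 2 to compound 3 (0.48 log units; beyond the scatter), and furan-2-yl in place of 4-methoxyphenyl gives a 3.3-fold higher number from compound 1 to compound 3 (0.52 log units; beyond the scatter). The earlier exchange on the six-membered ring, fluoro in place of methoxy, gave only a 1.1-fold higher number from compound 1 to compound 2 (0.04 log units; within the scatter), so in these three compounds replacing the whole aromatic group moves the number beyond the scatter, while changing that one ring substituent does not. No measurement at hand accounts for the shift in either step.

Furan-2-yl differs from both six-membered groups in ring size, in its ring oxygen and in having no fluoro or methoxy substituent, and the three compounds cannot separate these differences. From the compounds shown here alone, whether the higher number belongs to the five-membered ring or to the missing substituent remains open, and thiophen-2-yl or unsubstituted phenyl at this place would bear directly on that question.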